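The source may hold more compounds than are shown below. What is called first, only, known or untested is meant among the compounds shown, and "the series" means these compounds.

Compound 1 `COc1cc(-c2nnc(SCc3ccc(C)cc3)o2)ccc1O`: 6210 nM
Compound 2 `COc1cc(-c2nnc(SCc3ccc(Cl)cc3)o2)ccc1O`: 11100 nM
Compound 3 `COc1cc(-c2nnc(SCc3cccc(Cl)c3)o2)ccc1O`: 8290 nM

All three were tested in a functional assay on cells (T-cell, Mus musculus, strain BALB/c) for inhibition, read by MTT assay, with stated times of 24 h and 72 h; on this read-out lower numbers stand for stronger inhibition and higher numbers for weaker inhibition. Compound 1 gives the lowest of the three numbers, yet its gap to compound 3 is a 1.3-fold higher number from compound 1 to compound 3 (0.13 log units; within the scatter) and its gap to compound 2 is a 1.8-fold higher number from compound 1 to compound 2 (0.25 log units; within the scatter), both within the scatter, so the three compounds cannot be set in order.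

Compound 4 `COc1cc(-c2nnc(SCc3ccc(Br)cc3)o2)ccc1O` is not yet measured. Its difference from compound 1 is bromo in place of methyl on an aromatic carbon.

Among the measured compounds shown here, the step that bears most directly on this change is the one from compound 1 to compound 2, in which chloro took the place of the same methyl: a 1.8-fold higher number from compound 1 to compound 2 (0.25 log units; within the scatter). The step from compound 2 to compound 3, which moved the chloro to another place on the ring, was a 1.3-fold lower number from compound 2 to compound 3 (0.13 log units; within the scatter). Neither step left the scatter. A halogen in place of methyl at this spot therefore is expected to give, in this assay, a step of about a 1.4-fold higher number from compound 1 to compound 4 (0.16 log units; within the scatter), not beyond the scatter. Compound 4 is estimated at 9000 nM, within 4500 nM to 18000 nM.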

Compound 4, half-maximal inhibitory concentration: 8830 nM
The estimate for compound 4 lay 1.0-fold (0.01 log units) above the measured number; the range from low to high includes it.
By their numbers in this assay, from the lowest: compounds 1, 3, 4 and 2 (each within the scatter of the next).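

In this assay bromo, on an aromatic carbon para to a large group, joins methyl and chloro at this position, and the result is again a small step (a 1.4-fold higher number from compound 1 to compound 4 (0.15 log units; within the scatter)). The halogen swap is just as small (a 1.3-fold lower number from compound 2 to compound 4 (0.10 log units; within the scatter)), and so is the gap to the compound with its chloro elsewhere on the ring (a 1.1-fold higher number from compound 3 to compound 4 (0.03 log units; within the scatter)), so methyl, chloro and bromo here cannot be told apart, and a heavier halogen does not separate from the lighter one in this assay. Nothing available explains why these numbers lie so close together.

Going by these compounds, whether a different kind of group at this spot, such as an amine or a carboxylic acid, would give a step beyond the scatter remains open. Also open, on these data alone, is whether a change elsewhere on the shared core, such as a longer chain on the sulfur, would matter more.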